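A few compounds are considered here, and "the series" means these few. Any claim that something is new, unique, unknown or untested is made for them only; others in the source may bear on it.

Compound 1, `O=C(CN(c1ncnc2c1ncn2C1CCCCO1)C1CC1)N[C@@H](CO)C(=O)OCc1ccccc1`: 29.2%
Compound 2, `CSCC[C@H](NC(=O)CN(c1nc(Cl)nc2[nH]cnc12)C1CC1)C(=O)OCc1ccccc1`: 31.6%
Compound 3, `O=C(CN(c1nc(Cl)nc2[nH]cnc12)C1CC1)N[C@@H](CC(=O)OCc1ccccc1)C(=O)OCc1ccccc1`: 12.1%

All three were measured in a functional assay on the whole organism (Tail, strain ICR) with Mus musculus as the target, in the tail flick test, with a stated time of 120 min, at a dose of 25 umol/kg by the oral route; on this read-out lower numbers stand for a weaker effect and higher numbers for a stronger effect at the one dose given. Compound 1 stands second highest of the three: its value and that of compound 2 lie within the usual scatter of each other, while compound 3 sits below both, beyond the scatter. The unmeasured compound 4, `NC(=O)CC[C@H](NC(=O)CN(c1ncnc2c1ncn2C1CCCCO1)C1CC1)C(=O)OCc1ccccc1`, differs from compound 1 in one place: carbamoylmethyl in place of hydroxy on a saturated chain carbon, two bonds along the chain from an amide-type nitrogen and a carbonyl carbon. Among the compounds with values here, the only measured step at that same place on the chain is a number 19.5 percentage points lower from compound 2 to compound 3 (beyond the scatter), where one group replaced another and the activity fell. That step, however, was made on a different core and with different groups, so it guides only loosely. Because a number 19.5 percentage points lower from compound 2 to compound 3 (beyond the scatter) points downward, a modest fall, or no change beyond the scatter, is the expected outcome here. The expected step is a number 7.2 percentage points lower from compound 1 to compound 4 (within the scatter). Compound 4 is therefore estimated to give about 22%, with a likely range from 8% to 38%.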

Compound 4, a percentage reported as activity, at one dose (the size of the read-out at that dose, not a potency): 22.3%
Beside the measured number, compound 4's estimate is 0.3 percentage points below it; the range from low to high includes it.
By their numbers in this assay, from the lowest: compound 3; then compounds 4, 1 and 2 (each within the scatter of the next).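

In this assay, putting carbamoylmethyl in place of hydroxy on this saturated chain carbon gives a number 6.9 percentage points lower from compound 1 to compound 4 (within the scatter) and so cannot be told apart from repeat noise. On the core of compound 1, then, the position takes a group of 4 heavy atoms in place of 1 with no change beyond the scatter, whereas the earlier step at this place, a number 19.5 percentage points lower from compound 2 to compound 3 (beyond the scatter) on a different core, did go beyond it. Nothing shown here offers an explanation for this result.

Left open is how this assay would read with an amine or a carboxylic acid at the end of this chain, or with a longer chain. On these data alone, it is also open whether the same swap would read alike on the core of compound 2.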